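Methyl for Methoxy on Two Pyrazole Cores

This account rests on a few compounds, and the source may have more. Where it says the series, first, only, none or still open, it means among the compounds named here.

Compound 1, `Cc1ccc(CSc2nc3nc(C)cc(Nc4cc(-c5ccccc5)[nH]n4)n3n2)cc1`, in an ADME assay on GES1 cells (Homo sapiens) for inhibition, read by MTT assay, with a stated time of 72 h (on this read-out higher numbers stand for weaker inhibition and lower numbers for stronger inhibition), gives 36200 nM.
Compound 2, `COc1ccc(CSc2nc3nc(C)cc(Nc4cc(-c5ccccc5)[nH]n4)n3n2)cc1`, in this assay gives 28200 nM.
Compound 3, `COc1ccc(Cn2ccc(Nc3cc(C)nc4nc(SCc5ccc(Br)cc5)nn34)n2)cc1`, in this assay gives > 50000 nM, which is a limit of the assay and not a number.

Compound 1 and compound 2 share one core and differ in a single place: methyl in place of methoxy on an aromatic carbon. The step this change makes is a 1.3-fold higher number from compound 2 to compound 1 (0.11 log units; within the scatter), so the two values stand within the usual scatter of each other and no order between them can be read.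

Compound 3 is built on a different core; how its core differs from that of compound 2 is not broken down here. For compound 3 only a limit is known: the limit of > 50000 nM in this assay, at which 1 of the 3 values shown sits.

Compound 4, `Cc1ccc(Cn2ccc(Nc3cc(C)nc4nc(SCc5ccc(Br)cc5)nn34)n2)cc1`, has not yet been measured in this assay. It differs from compound 3 by methyl in place of methoxy on an aromatic carbon, the same change that separates compound 2 from compound 1, at the same kind of place on the ring.

Resting on a 1.3-fold higher number from compound 2 to compound 1 (0.11 log units; within the scatter), the step from compound 3 to compound 4 is expected to be small, a step that the limit leaves unreadable from compound 3 to compound 4, and since compound 3 sits at the limit of the assay, compound 4 is expected to come back as a limit as well more often than as a number. Compound 4 is estimated at about 60000 nM, with a range from 30000 nM to 150000 nM.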

Compound 4, half-maximal inhibitory concentration: > 50000 nM
Compound 4: only a limit was reported; the forecaster's own chance of this, stated with the estimate: 70%; the middle value does not contradict the limit.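

In this assay compound 4 gives > 50000 nM, which is a limit of the assay and not a number. Within the data shown here, compound 3 also stands at a limit, so no step from compound 3 to compound 4 can be read: the limit of > 50000 nM in this assay, at which 2 of the 4 values shown sit. The compounds shown leave open whether methyl in place of methoxy on an aromatic carbon changes the value at all on the core of compound 3.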